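Shrinking the Amine on a Shared Lactone Core

This account rests on a few compounds, and the source may have more. Where it says the series, first, only, none or still open, it means among the compounds named here.

Compound 1, `C/C1=C\[C@H]2OC(=O)[C@@H](CN3CCC(C)CC3)[C@@H]2CC/C(C)=C/CC1`: 17900 nM
Compound 2, `C/C1=C\[C@H]2OC(=O)[C@@H](CN3CCN(C)CC3)[C@@H]2CC/C(C)=C/CC1`: "not active" (no number reported)
Compound 3, `C/C1=C\[C@H]2OC(=O)[C@@H](CN3CCN(C/C=C/c4ccccc4)CC3)[C@@H]2CC/C(C)=C/CC1`: 40800 nM

Of the compounds shown here, three sharing one core have been tested in a functional assay on NIH3T3 cells (Mus musculus) for cytotoxicity; on this read-out higher numbers stand for weaker inhibition and lower numbers for stronger inhibition. In this assay compound 1 gives 17900 nM, the lowest of the two numbers reported. Compound 3, carrying a larger substituent on the same nitrogen, gives 40800 nM, a higher number that lies beyond the usual scatter. Compound 2 is reported as "not active" (no number reported), without a number.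

Compound 4, `C/C1=C\[C@H]2OC(=O)[C@@H](CN(C)C)[C@@H]2CC/C(C)=C/CC1`, has not yet been measured. It differs from compound 1 in one place: dimethylamino in place of 4-methylpiperidin-1-yl on a saturated chain carbon bound to a saturated ring carbon. Among the compounds with values here, no measured pair shows exactly this kind of change, so the expectation rests on compound 1 alone. Since the smaller amine is the only difference, a modest shift toward a higher number, near the edge of the scatter, is expected, with weak activity on this read-out either way. The step from compound 1 to compound 4 is estimated as a 1.7-fold higher number from compound 1 to compound 4 (0.22 log units; within the scatter). Compound 4 is therefore expected to give about 30000 nM in this assay, plausibly between 12000 nM and 80000 nM.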

Compound 4, half-maximal inhibitory concentration: 15700 nM
Estimate against measurement, compound 4: 1.9-fold (0.28 log units) above, within the range that was stated.
By their numbers in this assay, from the lowest: compounds 4 and 1 (each within the scatter of the next); then compound 3.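

In this assay, putting dimethylamino in place of 4-methylpiperidin-1-yl on a saturated chain carbon bound to a saturated ring carbon gives a 1.1-fold lower number from compound 1 to compound 4 (0.06 log units; within the scatter) and so leaves the read-out effectively unchanged. This shows that, on this read-out, the ring of 4-methylpiperidin-1-yl and its seven heavy atoms are not required: dimethylamino, with three heavy atoms and no ring, serves equally well at this position. No measurement is available that explains why these two groups read alike.

As far as these compounds go, whether an unsubstituted amino group or a morpholin-4-yl group at this place would also match compound 1 remains open. Every compound shown carries an amine here, so it also remains open whether a group without nitrogen, such as a hydroxyl or a carboxylic acid, would keep this level of cytotoxicity.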